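Moving the methoxy on the triazole aryl: compound 4

The source may report more compounds than this note shows. Statements on the series, on what has been measured and on what is new or still open speak of the compounds shown alone.

Compound 1 `CCc1ccccc1-n1nncc1CN1C(=O)C2(C(C#N)=C(N)Oc3c(N)cc4nc5ccccc5nc4c32)c2ccccc21`: 24600 nM
Compound 2 `CC(=O)Nc1ccc(-n2nncc2CN2C(=O)C3(C(C#N)=C(N)Oc4c(N)cc5nc6ccccc6nc5c43)c3ccccc32)cc1`: > 50000 nM
Compound 3 `COc1ccc(-n2nncc2CN2C(=O)C3(C(C#N)=C(N)Oc4c(N)cc5nc6ccccc6nc5c43)c3ccccc32)cc1`: > 50000 nM

In a functional assay on MCF7 cells (Homo sapiens) for antiproliferative activity, read by MTT assay, with a stated time of 48 h (a higher number here means a weaker inhibitor, a lower number a stronger inhibitor), compound 3 gives only a limit of the assay, > 50000 nM. Compound 2 likewise gives a limit, > 50000 nM. Compound 1 alone gives a number, 24600 nM. Compound 4 `COc1ccccc1-n1nncc1CN1C(=O)C2(C(C#N)=C(N)Oc3c(N)cc4nc5ccccc5nc4c32)c2ccccc21` differs from compound 3 by 2-methoxyphenyl in place of 4-methoxyphenyl on an aromatic nitrogen. Going by the values given here, the steps that bear on it are an at least 2.0-fold higher number from compound 1 to compound 3 (0.30 log units; that floor lies within the scatter) and an at least 2.0-fold higher number from compound 1 to compound 2 (0.30 log units; that floor lies within the scatter), both ending at the limit of > 50000 nM in this assay, at which 2 of the 3 values shown sit; the step that the two limits leave unreadable from compound 2 to compound 3 cannot be sized. Compound 1, which also carries a group with a substituent in the 2-position on that aromatic nitrogen, is the only point with a readable number. Compound 4 is therefore expected near 40000 nM, between 15000 nM and 150000 nM, a step of an at least 1.2-fold lower number from compound 3 to compound 4 (0.09 log units; that floor lies within the scatter), with a fair chance that only a limit is reported.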

Compound 4, half-maximal inhibitory concentration: 28900 nM
Beside the measured number, compound 4's estimate is 1.4-fold (0.14 log units) above it, within the range that was stated.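

In this assay, 2-methoxyphenyl in place of 4-methoxyphenyl turns a limit into a readable number, with an at least 1.7-fold lower number from compound 3 to compound 4 (0.23 log units; that floor lies within the scatter) as the step, and the comparison with the acetamido compound gives an at least 1.7-fold lower number from compound 2 to compound 4 (0.23 log units; that floor lies within the scatter) in the same direction. Methoxy and ethyl on the same aryl position are not separated, with a 1.2-fold higher number from compound 1 to compound 4 (0.07 log units; within the scatter) as their step. Among these four compounds, only the two with a 2-substituted aryl group give a number, while compound 2 and compound 3 remain at a limit: the limit of > 50000 nM in this assay, at which 2 of the 4 values shown sit.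

On these data alone, the true size of the change stays unknown while compound 3 gives only a limit. As far as these compounds go, it also remains open whether an amine or a carboxylic acid in place of that methoxy would still give a readable number.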